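This account rests on a few compounds, and the source may have more. Where it says the series, first, only, none or still open, it means among the compounds named here.

Working notes on the series.

Within the data shown here, the three compounds measured so far share one core and differ only in the aryl group on the urea nitrogen. Compound 1 `CCOc1ccc(NC(=O)Nc2cccc(CNc3nccnc3Cl)c2)cc1` gives 7050 nM in a functional assay on HepG2 cells (Homo sapiens) for antiproliferative activity, read by MTT assay, with a stated time of 48 h; on this read-out lower numbers stand for stronger inhibition and higher numbers for weaker inhibition. Compound 2 `O=C(Nc1ccccc1)Nc1cccc(CNc2nccnc2Cl)c1` gives 15600 nM in this assay, and compound 3 `Cc1ccc(NC(=O)Nc2cccc(CNc3nccnc3Cl)c2)cc1Cl` gives 11300 nM. Compound 2 thus stands with the highest number of the three: a 2.2-fold higher number from compound 1 to compound 2 (0.34 log units; beyond the scatter) lies beyond the scatter, whereas a 1.4-fold lower number from compound 2 to compound 3 (0.14 log units; within the scatter) does not, so compound 2 and compound 3 are not told apart on this read-out.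

The next compound, compound 4 `CC(C)(C)c1ccc(NC(=O)Nc2cccc(CNc3nccnc3Cl)c2)cc1`, differs from compound 2 by tert-butyl in place of hydrogen on an aromatic carbon.

Among the measured compounds shown here, the step that bears most directly on this change is the one from compound 1 to compound 2, in which the number rose modestly when a substituent on the same aromatic carbon was removed; read backwards, putting a group onto that carbon lowered the number. The change from compound 2 to compound 3, which alters the same aryl group elsewhere, stayed within the scatter. On that basis a modest lowering of the number, or at most a step of the size seen between compound 1 and compound 2, is expected in this assay for compound 4, that is a 1.7-fold lower number from compound 2 to compound 4 (0.24 log units; within the scatter).

The estimate for compound 4 is therefore 9000 nM, with a range from 4500 nM to 18000 nM.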

Compound 4, half-maximal inhibitory concentration: 7550 nM
For compound 4 the middle estimate is 1.2-fold (0.08 log units) above the measured one, and the stated range covers the measured number.
By their numbers in this assay, from the lowest: compounds 1, 4, 3 and 2 (each within the scatter of the next, the first and the last beyond it).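

In this assay, tert-butyl on this aromatic carbon, para to a large group, gives a 2.1-fold lower number from compound 2 to compound 4 (0.32 log units; beyond the scatter), so a second and purely carbon substituent also goes with a lower number than hydrogen, alongside the ethoxy of compound 1. The comparison of the two substituents gives a 1.1-fold higher number from compound 1 to compound 4 (0.03 log units; within the scatter), so ethoxy and tert-butyl are not told apart on this read-out, and among these compounds the oxygen of ethoxy is not needed for the step away from hydrogen. No measurement is available here that explains either step.

From the compounds shown here alone, whether the same lowering holds for an amine, a carboxylic acid or a longer chain such as n-hexyl on this carbon remains open, and with only ethoxy and tert-butyl to compare with hydrogen at this position, no trend with the size or type of substituent can be drawn. It also remains open whether the step would persist on a different core, as every compound shown shares the core of compound 1.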